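Removing the ethyl branch on the acid chain of compound 2

A few compounds are considered here, and "the series" means these few. Any claim that something is new, unique, unknown or untested is made for them only; others in the source may bear on it.

Of the compounds shown here, three have been measured in an assay on membranes from lung (Cavia porcellus) for binding affinity to cysteinyl leukotriene receptor (Homo sapiens); a higher number here means a weaker inhibitor, a lower number a stronger inhibitor. Compound 1 `CC(CCc1nnn[nH]1)Cc1ccc(OCc2ccc3ccccc3n2)cc1` gives 12 nM, compound 3 `CC(CCc1ccc(OCc2ccc3ccccc3n2)cc1)Cc1nnn[nH]1` gives 25 nM, and compound 2 `CCCC(CCC(=O)O)Cc1cccc(OCc2ccc3ccccc3n2)c1` gives 50 nM. Compound 2 thus carries the highest of the three numbers, though its gap to compound 3 lies within the scatter; only the gap to compound 1 lies beyond it. For the measured compounds named here, the one step measured so far, a 2.1-fold higher number from compound 1 to compound 3 (0.32 log units; beyond the scatter), concerns where the tetrazole sits on the chain, not the branch on the acid chain.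

Compound 4 `CC(CCC(=O)O)Cc1cccc(OCc2ccc3ccccc3n2)c1` differs from compound 2 by hydrogen in place of ethyl on a saturated chain carbon, three bonds along the chain from an aromatic carbon. Going by the values given here, no measured step touches this part of the structure, so nothing in the data shows whether the ethyl branch matters in this assay. The expectation is therefore carried over from compound 2 unchanged, and the step of a 1.1-fold lower number from compound 2 to compound 4 (0.05 log units; within the scatter) is estimated to lie within the scatter. On that basis compound 4 is expected to give about 45 nM in this assay, with a range of 18 nM to 115 nM to cover the possibility that the branch does shift binding either way.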

Compound 4, inhibition constant: 140 nM
The estimate for compound 4 lay 3.1-fold (0.49 log units) below the measured number, outside the stated range (above it).
By their numbers in this assay, from the lowest: compound 1; then compounds 3 and 2 (each within the scatter of the next); then compound 4.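

In this assay, for the compounds shown here, this is the first reading of the branch on the acid chain, and the branch is not neutral: a 2.8-fold higher number from compound 2 to compound 4 (0.45 log units; beyond the scatter). Hydrogen in place of ethyl on this saturated chain carbon, three bonds along the chain from an aromatic carbon, therefore gives a weaker inhibitor, by a modest step that lies beyond the scatter. Cut one bond further out, the same difference reads propyl to methyl, so within this pair the longer chain goes with the lower number, a statement that rests on these two compounds alone and on no wider trend in the series. Nothing available bears on why the removal of two carbons shifts binding in this way.

The compounds shown leave open how the number responds to chain size at this carbon, since only ethyl and hydrogen can be compared there, and a butyl chain or a cyclopropyl ring in the same place would show whether the gain continues or stops. Going by these compounds alone, they also leave open whether the ethyl branch has a similar effect on the tetrazole compounds, as the only step read at this carbon belongs to the carboxylic acid pair.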